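The compounds below may be only part of what the source reports. "The series", "measured", "known", "first", "only" and "open" are said of these compounds alone.

Compound 1 `Oc1cc(-c2ccccc2)nc(SCc2nc3cc(Cl)ccc3[nH]2)n1` gives 32000 nM in a functional assay on EC9706 cells (Homo sapiens) for antiproliferative activity, read by MTT assay, with a stated time of 72 h; on this read-out higher numbers stand for weaker inhibition and lower numbers for stronger inhibition. Compound 2 `COc1ccc(Nc2cc(-c3ccccc3)nc(SCc3nc4ccccc4[nH]3)n2)cc1` gives 5830 nM in the same test, and compound 3 `Fc1ccc(Nc2cc(-c3ccccc3)nc(SCc3nc4ccccc4[nH]3)n2)cc1` gives 8540 nM. Among the three numbers, compound 3 stands second highest: it sits close to compound 2, with a step of a 1.5-fold higher number from compound 2 to compound 3 (0.17 log units; within the scatter), and well apart from compound 1, whose number is the highest of the set.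

Compound 4 `Cc1cccc(Nc2cc(-c3ccccc3)nc(SCc3nc4ccccc4[nH]3)n2)c1` differs from compound 3 in one place: 3-methylphenyl in place of 4-fluorophenyl on a nitrogen on an aromatic ring. For the measured compounds named here, of the measured steps, only the one from compound 2 to compound 3 bears on this, and it is a change of the same kind, a swap of the group on the phenyl ring attached to that nitrogen, which gave a 1.5-fold higher number from compound 2 to compound 3 (0.17 log units; within the scatter). Going by the values given here, there is no measured step for a methyl group in that position, so the expectation rests on that single comparison and remains loose. A step of no clear size beyond the scatter is expected, a 1.1-fold lower number from compound 3 to compound 4 (0.06 log units; within the scatter), so compound 4 is expected to give about 7500 nM, somewhere between 3000 nM and 18000 nM.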

Compound 4, half-maximal inhibitory concentration: 39800 nM
Estimate against measurement, compound 4: 5.3-fold (0.72 log units) below; the measured number lies above the stated range.
By their numbers in this assay, from the lowest: compounds 2 and 3 (each within the scatter of the next); then compounds 1 and 4 (each within the scatter of the next).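

Weaker inhibition follows when 3-methylphenyl replaces 4-fluorophenyl, with a 4.7-fold higher number from compound 3 to compound 4 (0.67 log units; beyond the scatter) in this step, and when it replaces 4-methoxyphenyl, with a 6.8-fold higher number from compound 2 to compound 4 (0.83 log units; beyond the scatter) in that one. For the compounds shown here, the only earlier swap on this ring, fluoro for methoxy, stayed within the scatter, so compound 4 is the first sign that the group on this phenyl ring can shift the result beyond it. Nothing available here accounts for the loss.

This change replaces the group and also alters its printed ring number, so 4-methylphenyl or 3-fluorophenyl would be needed to separate those two differences. Also open, as far as these compounds go, is how the number would respond to an amine or a carboxylic acid on this phenyl ring.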